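What one added methoxy may do to compound 1

The source may report more compounds than this note shows. Statements on the series, on what has been measured and on what is new or still open speak of the compounds shown alone.

Measured so far in an ADME assay on HEK293 cells (Homo sapiens) for cytotoxicity, read by MTT assay (a lower number here means a stronger inhibitor, a higher number a weaker inhibitor), as follows
Compound 1 `Cc1cc(O)c(C(=O)/C=C/c2ccc(C(F)(F)F)cc2)c(=O)o1` gives 100000 nM
Compound 2 `COc1ccc(/C=C/C(=O)c2c(O)cc(C)oc2=O)cc1` gives 100000 nM

Compound 1 stands level with compound 2 on these numbers, so neither can be called the stronger. Compound 3 `COc1cc(C(F)(F)F)ccc1/C=C/C(=O)c1c(O)cc(C)oc1=O` has not been measured yet. It keeps the trifluoromethyl group of compound 1 and gains one group on the aromatic ring: methoxy in place of hydrogen on an aromatic carbon. Within the data shown here, only one measured step bears on this, namely no change at the digits printed from compound 1 to compound 2 (within the scatter). That step also brings in a methoxy, but in place of trifluoromethyl rather than hydrogen, so it is a limited guide. On this evidence, no step beyond the scatter is expected in this assay, and no direction can be favoured. The expected size is no change at the digits printed from compound 1 to compound 3 (within the scatter) in all. Compound 3 is estimated at 100000 nM with 50000 nM to 200000 nM as the expected range.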

Compound 3, half-maximal inhibitory concentration: 100000 nM
Beside the measured number, compound 3's estimate shows no gap at the digits printed; the measured number falls inside the stated range.
By their numbers in this assay, from the lowest: compounds 1, 2 and 3 (each within the scatter of the next).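

In this assay, methoxy in place of hydrogen, on an aromatic carbon ortho to a large group and meta to a trifluoromethyl group, gives no change at the digits printed from compound 1 to compound 3 (within the scatter) in this series. The earlier pair showed methoxy taking the place of trifluoromethyl, whereas compound 3 carries both groups on the same ring, and its number still does not separate it from compound 1. Nothing measured here accounts for this sameness.

What the compounds shown leave open is whether any group at this carbon can move the number at all, for example an amine, a carboxylic acid, or a longer chain such as ethoxy. They also leave open whether methoxy would behave in the same way on another carbon of the ring, or on a core other than that of compound 1.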